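A few compounds are considered here, and "the series" means these few. Any claim that something is new, unique, unknown or untested is made for them only; others in the source may bear on it.

Measured compounds:
- Compound 1 `CCCCCCCn1ccc2cc(/C(C)=C/C(=O)Nc3ccccc3OCCCC(=O)O)ccc21`: 120 nM
- Compound 2 `CCCCC(CC)n1ccc2cc(/C(C)=C/C(=O)Nc3ccccc3OCCCC(=O)O)ccc21`: 7.1 nM
- Compound 3 `C/C(=C\C(=O)Nc1ccccc1OCCCC(=O)O)c1ccc2c(ccn2Cc2cccc(C)c2)c1`: 250 nM

These three compounds share one core and differ only in the group carried on the aromatic nitrogen. In an assay on Prostate gland for inhibition of steroid 5-alpha-reductase (Rattus norvegicus) (a lower number here means a stronger inhibitor, a higher number a weaker inhibitor), compound 1 gives 120 nM, the second highest of the three numbers: compound 2 lies far below it, a 17-fold lower number from compound 1 to compound 2 (1.23 log units; beyond the scatter), while compound 3 lies a little above it, a 2.1-fold higher number from compound 1 to compound 3 (0.32 log units; beyond the scatter).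

Compound 4 `COc1ccc(Cn2ccc3cc(/C(C)=C/C(=O)Nc4ccccc4OCCCC(=O)O)ccc32)cc1` has not yet been measured. It differs from compound 1 in one place: 4-methoxyphenyl in place of hexyl on a saturated chain carbon bound to an aromatic nitrogen. The closest guide is the change from compound 1 to compound 3, where a 3-methylphenyl also replaced hexyl on the saturated chain carbon bound to the aromatic nitrogen and gave only a modest rise, a 2.1-fold higher number from compound 1 to compound 3 (0.32 log units; beyond the scatter). The step from compound 2 to compound 3, a 35-fold higher number from compound 2 to compound 3 (1.55 log units; beyond the scatter), shows the same aromatic replacement costing far more when the starting group is 1-ethylpentyl. For compound 4 a modest rise is therefore expected, about a 2.1-fold higher number from compound 1 to compound 4 (0.32 log units; beyond the scatter). The expected value for compound 4 in this assay is 250 nM, with a range from 100 nM to 650 nM.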

Compound 4, half-maximal inhibitory concentration: 480 nM
Compound 4: the middle estimate sits 1.9-fold (0.28 log units) below what was measured; the range from low to high includes it.
By their numbers in this assay, from the lowest: compound 2; then compound 1; then compounds 3 and 4 (each within the scatter of the next).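

In this assay, within the data shown here, the 4-methoxyphenyl group again raises the number when it replaces hexyl on the saturated chain carbon bound to the aromatic nitrogen, giving a 4.0-fold higher number from compound 1 to compound 4 (0.60 log units; beyond the scatter), so compound 3 is no longer the only aromatic example to fall short of the straight chain. Exchanging one aromatic group for the other gives a 1.9-fold higher number from compound 3 to compound 4 (0.28 log units; within the scatter), so these two groups cannot be told apart here, even though they differ in the added group they carry, while the branched chain keeps a wide lead, with a 68-fold higher number from compound 2 to compound 4 (1.83 log units; beyond the scatter). What lies behind these differences cannot be said, as nothing here explains them.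

The compounds shown leave open whether a plain unsubstituted benzyl, or a benzyl carrying a chlorine or a hydroxyl group, would read like compounds 3 and 4 or would come closer to compound 2. They also leave open whether the large gain belongs to 1-ethylpentyl alone or extends to other branched or ring-bearing groups on the aromatic nitrogen, such as 1-propylbutyl or cyclohexylmethyl.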